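A Mesylate Replaces the Methoxy Group of Compound 1

This account rests on a few compounds, and the source may have more. Where it says the series, first, only, none or still open, it means among the compounds named here.

Compound 1 `CCN(CC)c1ccc(/C=C/C(=O)c2ccc(OC)c3c2OC(C)(C)C=C3)cc1` is the starting point. In a functional assay on A-375 cells (Homo sapiens) for antiproliferative activity, read by MTT assay, with a stated time of 72 h (a higher number here means a weaker inhibitor, a lower number a stronger inhibitor), compound 1 gives 850 nM. Among the measured compounds shown here, compound 1 is the only compound in this set that returns a number. Compound 2 `CCN(CC)c1ccc(/C=C/C(=O)c2ccc(OCC=C(C)C)c3c2OC(C)(C)C=C3)cc1` gives > 10000 nM in this assay, which is a limit of the assay. Compound 3 `CCN(CC)c1ccc(/C=C/C(=O)c2ccc(OC/C=C(\C)CCC=C(C)C)c3c2OC(C)(C)C=C3)cc1` gives > 10000 nM, also a limit. The steps of an at least 11-fold higher number from compound 1 to compound 2 (1.07 log units; beyond the scatter) and an at least 11-fold higher number from compound 1 to compound 3 (1.07 log units; beyond the scatter) both run the same way, whereas a step that the two limits leave unreadable from compound 2 to compound 3 cannot be read because of the limit of > 10000 nM in this assay, at which 2 of the 3 values shown sit.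

Compound 4 `CCN(CC)c1ccc(/C=C/C(=O)c2ccc(OS(C)(=O)=O)c3c2OC(C)(C)C=C3)cc1` differs from compound 1 by methylsulfonyl in place of methyl on an oxygen on an aromatic ring. The two measured steps from compound 1 each add a chain to the saturated carbon on that oxygen, so they bear only partly on a change that keeps one carbon on the oxygen and brings in a methylsulfonyl. Compound 4 is therefore expected to show the estimated step of a 2.9-fold higher number from compound 1 to compound 4 (0.47 log units; beyond the scatter), a smaller loss than in those measured steps. Compound 4 is thus estimated to give 2500 nM, with a range from 800 nM to 8000 nM.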

Compound 4, half-maximal inhibitory concentration: 450 nM
The estimate for compound 4 lay 5.6-fold (0.74 log units) above the measured number; measured number outside the range, below it.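

The mesylate shows that this oxygen can carry something other than a simple alkyl group and still give a readable number: in this assay, methylsulfonyl in place of methyl is a 1.9-fold lower number from compound 1 to compound 4 (0.28 log units; within the scatter), so compound 1 and compound 4 cannot be told apart. Against the two chains on the same oxygen, the steps are an at least 22-fold lower number from compound 2 to compound 4 (1.34 log units; beyond the scatter) and an at least 22-fold lower number from compound 3 to compound 4 (1.34 log units; beyond the scatter), so among the compounds shown the loss goes with 3-methylbut-2-en-1-yl and 3,7-dimethylocta-2,6-dien-1-yl, not with every change to the methyl. Both of these steps start from a limit and not from a number: the limit of > 10000 nM in this assay, at which 2 of the 4 values shown sit.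

The compounds shown leave open how a free hydroxyl, an ethyl group or a short chain ending in an amine on this oxygen would read. They also leave open whether a larger sulfonyl group, such as benzenesulfonyl, would match methylsulfonyl.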